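A few compounds are considered here, and "the series" means these few. Any claim that something is new, unique, unknown or untested is made for them only; others in the source may bear on it.

Two members of the series are in hand. Compound 1 `CC(=O)N1N=C(c2ccc(-n3cncn3)cc2)CC1c1ccc(N(C)C)cc1` gives -0.3% in a functional assay on NCI-H1975 cells (Homo sapiens) for inhibition, read by sulforhodamine B assay, tested at 10 uM; on this read-out higher numbers stand for more inhibition at the one concentration tested (going by the name of the read-out) and lower numbers for less inhibition; compound 2 `COC(=O)CC(=O)N1N=C(c2ccc(-n3cncn3)cc2)CC1c1ccc(N(C)C)cc1` gives 1.5%. Among the measured compounds shown here, compound 2 stands highest of the two numbers, but the only measured step, a number 1.8 percentage points higher from compound 1 to compound 2 (within the scatter), lies within the scatter. Compound 3 `CN(C)c1ccc(C2CC(c3ccc(-n4cncn4)cc3)=NN2C(=O)c2cc(Cl)cc(Cl)c2)cc1` is not yet measured. For the measured compounds named here, its change from compound 2, (3,5-dichlorophenyl in place of (methoxycarbonyl)methyl on a carbonyl carbon), has no measured counterpart, and the single step in hand is of a different kind, so it offers no direction. Expected for compound 3 is no step beyond the scatter, a number 2.5 percentage points higher from compound 2 to compound 3 (within the scatter). Compound 3 is therefore estimated at 4%, between -14% and 24%.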

Compound 3, a percentage reported as inhibition, at one concentration (the size of the read-out at that concentration, not a potency): 8.4%
The estimate for compound 3 lay 4.4 percentage points below the measured number; the measured number falls inside the stated range.
By their numbers in this assay, from the lowest: compounds 1, 2 and 3 (each within the scatter of the next).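

Placing an aromatic ring on the carbonyl carbon, whose other neighbour is the amide-type nitrogen in a ring, still gives no step beyond the scatter in this assay. For 3,5-dichlorophenyl in place of (methoxycarbonyl)methyl the result is a number 6.9 percentage points higher from compound 2 to compound 3 (within the scatter), and for 3,5-dichlorophenyl in place of methyl it is a number 8.7 percentage points higher from compound 1 to compound 3 (within the scatter). No evidence bears on these steps.

Open, on these data alone, is whether phenyl without chlorine, a pyridine ring or a longer chain ending in a carboxylic acid on this carbonyl carbon gives a step beyond the scatter. As far as these compounds go, all compounds here share the rest of the core, so changes elsewhere also remain open.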